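This account rests on a few compounds, and the source may have more. Where it says the series, first, only, none or still open, it means among the compounds named here.

Measured in a functional assay on MGC-803 cells (Homo sapiens) for antiproliferative activity, read by MTT assay, with a stated time of 72 h; on this read-out higher numbers stand for weaker inhibition and lower numbers for stronger inhibition:
- compound 1 `O=C1OCC[C@@H]1NC(=S)SCCOc1ccc([N+](=O)[O-])cc1`: > 100000 nM
- compound 2 `O=C1OCC[C@@H]1NC(=S)SCCOc1ccccc1`: 53800 nM
- compound 3 `Cc1cc(Cl)ccc1NCC(=O)N[C@H]1CCOC1=O`: > 64000 nM

The result for compound 1 is a limit, not a number. The result for compound 3, > 64000 nM, is also a limit. Among the compounds with values here, that leaves compound 2, at 53800 nM, as the only exact number.

Compound 4 `CCOc1ccccc1OCCSC(=S)N[C@H]1CCOC1=O` differs from compound 2 by one change: ethoxy in place of hydrogen on an aromatic carbon. Within the data shown here, only one measured step involves a swap on this aromatic ring, an at least 1.8-fold lower number from compound 1 to compound 2 (0.26 log units; that floor lies within the scatter), so it offers little guidance. No step beyond the usual scatter is therefore expected. The expected change is a 1.3-fold lower number from compound 2 to compound 4 (0.13 log units; within the scatter). For compound 4 the estimated value is 40000 nM, with an expected range from 12000 nM to 100000 nM.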

Compound 4, half-maximal inhibitory concentration: > 64000 nM
Compound 4 gave a limit, no number; the forecaster's own chance of this, stated with the estimate: 30%; at least 1.6-fold (0.20 log units) between middle value and limit.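

Ethoxy on an aromatic carbon, ortho to a large group, is the first change shown at this position, and in this assay compound 4 gives only a limit, not a number. On these data alone, the step is an at least 1.1-fold higher number from compound 2 to compound 4 (0.07 log units; that floor lies within the scatter), so it shows no stronger inhibition, while the true size of the step stays unknown. Compound 4 is not alone in ending at this limit: the limit of > 64000 nM in this assay, at which 2 of the 4 values shown sit.

As far as these compounds go, whether a methoxy group or an amine at this position would give an exact number, and how that number would compare with compound 2, remains open.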